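Thiophene in place of dimethylphenyl: an antiproliferative comparison

The compounds below may be only part of what the source reports. "The series", "measured", "known", "first", "only" and "open" are said of these compounds alone.

compound 1 `S=C(Nc1ccccc1)N1N=C(c2ccccc2Br)CC1c1ccc2c(c1)OCCO2` – 195000 nM
compound 2 `Cc1ccc(C2=NN(C(=S)Nc3ccccc3)C(c3ccc4c(c3)OCCO4)C2)cc1C` – 144000 nM

In a functional assay on HCT-116 cells (Homo sapiens) for antiproliferative activity, read by MTT assay, with a stated time of 48 h (a lower number here means a stronger inhibitor of growth, a higher number a weaker inhibitor of growth), compound 1 gives 195000 nM and compound 2 gives 144000 nM. Compound 2 has the lowest of the two numbers, but the step of a 1.4-fold lower number from compound 1 to compound 2 (0.13 log units; within the scatter) lies within the scatter, so the two are not separable. Compound 3 `S=C(Nc1ccccc1)N1N=C(c2cccs2)CC1c1ccc2c(c1)OCCO2` differs from compound 2 in one place: thiophen-2-yl in place of 3,4-dimethylphenyl on a carbon with a double bond to nitrogen. Among the measured compounds shown here, the only measured step that bears on this position is the one from compound 1 to compound 2, where a 2-bromophenyl was replaced by a 3,4-dimethylphenyl without a change beyond the scatter. The change to thiophen-2-yl is of a similar kind, so no step beyond the scatter is expected in this assay, in either direction. Compound 3 is therefore estimated at 160000 nM, with a range from 60000 nM to 400000 nM, corresponding to an expected step of a 1.1-fold higher number from compound 2 to compound 3 (0.05 log units; within the scatter).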

Compound 3, concentration for 50% growth inhibition: 8190 nM
For compound 3 the middle estimate is 20-fold (1.29 log units) above the measured one; the whole stated range lies above it.
By their numbers in this assay, from the lowest: compound 3; then compounds 2 and 1 (each within the scatter of the next).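

The position is not indifferent to what it carries, as the two substituted phenyl groups had suggested: in this assay the change to thiophen-2-yl gives a large step (an 18-fold lower number from compound 2 to compound 3 (1.25 log units; beyond the scatter)), and the step from the 2-bromophenyl compound is also large (a 24-fold lower number from compound 1 to compound 3 (1.38 log units; beyond the scatter)). Both steps lie beyond the scatter, so replacing a six-membered aromatic ring of carbon only with a five-membered aromatic ring with one hetero atom matters here, although exchanging one substituted phenyl for the other did not. No measurement shown explains why this exchange has such an effect.

With a single five-membered ring on hand, the compounds leave open whether the ring size, the sulfur or the loss of the phenyl substituents accounts for the step. As far as these compounds go, how an unsubstituted phenyl, a furan-2-yl or a thiophen-3-yl would compare at this position also remains open.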